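Replacing Isopropyl with Carboxymethyl on the Shared Core

The source may report more compounds than this note shows. Statements on the series, on what has been measured and on what is new or still open speak of the compounds shown alone.

Compound 2 `CC(C)c1ccc(N/N=C2\CCC(C)n3c2ncc(C(=O)O)c3=O)cc1` gives 2.4 umol/kg in a functional assay on the whole organism for inhibition, with Rattus norvegicus as the target (on this read-out higher numbers stand for an effect only at larger amounts of compound and lower numbers for an effect already at smaller amounts), the higher of the two numbers measured here. Among the measured compounds shown here, compound 1 `CC1CC/C(=N\Nc2ccc([N+](=O)[O-])cc2)c2ncc(C(=O)O)c(=O)n21` gives 0.8 umol/kg, and the step of a 3.0-fold higher number from compound 1 to compound 2 (0.48 log units; beyond the scatter) is the only measured change between them. Compound 3 `CC1CC/C(=N\Nc2ccc(CC(=O)O)cc2)c2ncc(C(=O)O)c(=O)n21` differs from compound 2 by carboxymethyl in place of isopropyl on an aromatic carbon. That single known step swapped a nitro group for isopropyl, so it bears only loosely on this change, and no clear direction beyond the scatter can be read from it. A small move back toward compound 1 is nonetheless expected, a 1.6-fold lower number from compound 2 to compound 3 (0.20 log units; within the scatter). Compound 3 is estimated at 1.5 umol/kg, between 0.5 umol/kg and 5 umol/kg.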

Compound 3, dose for 50% inhibition: 60.9 umol/kg
The estimate for compound 3 lay 41-fold (1.61 log units) below the measured number, and the stated range ends below it.
By their numbers in this assay, from the lowest: compound 1; then compound 2; then compound 3.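

Carboxymethyl on this aromatic carbon, para to a large group, raises the dose needed far more sharply than the earlier swap did: replacing isopropyl gives a 25-fold higher number from compound 2 to compound 3 (1.40 log units; beyond the scatter), and replacing nitro gives a 76-fold higher number from compound 1 to compound 3 (1.88 log units; beyond the scatter). So this position does not accept every group equally, and nitro and isopropyl stay much closer to each other than either does to carboxymethyl. Nothing available explains this jump.

Going by these compounds, it remains open whether the acid end of carboxymethyl or the chain itself drives the change. A methyl ester, a primary amide or a plain ethyl group at this carbon could help separate the two.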